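Swapping methyl for bromo on the benzyl group

The compounds below may be only part of what the source reports. "The series", "measured", "known", "first", "only" and "open" are said of these compounds alone.

Compound 2 `COc1cc(Oc2cccc(Nc3ccccc3)c2)cc(OC)c1CNCc1ccc(C)cc1` gives 13800 nM in a functional assay on HCT-116 cells (Homo sapiens) for inhibition, read by MTT assay, with a stated time of 72 h (a lower number here means a stronger inhibitor, a higher number a weaker inhibitor), the lower of the two numbers shown, though compound 1 `COc1cc(Oc2cccc(Nc3ccccc3)c2)cc(OC)c1CNCCNC(C)=O` at 18200 nM lies a 1.3-fold lower number from compound 1 to compound 2 (0.12 log units; within the scatter) away, within the scatter. In this assay compound 3 `COc1cc(Oc2cccc(Nc3ccccc3)c2)cc(OC)c1CNC1CC1` gives > 20000 nM, a limit and not a number. That value sits at the limit of > 20000 nM in this assay, at which 1 of the 3 values shown sits. Compound 4 `COc1cc(Oc2cccc(Nc3ccccc3)c2)cc(OC)c1CNCc1ccc(Br)cc1` differs from compound 2 by bromo in place of methyl on an aromatic carbon. Among the measured compounds shown here, no measured step touches this position: a 1.3-fold lower number from compound 1 to compound 2 (0.12 log units; within the scatter) and an at least 1.4-fold higher number from compound 2 to compound 3 (0.16 log units; that floor lies within the scatter) both change the group on the amine nitrogen, and neither reaches beyond the scatter. Compound 4 is therefore expected to move by a 1.1-fold lower number from compound 2 to compound 4 (0.03 log units; within the scatter), a step no larger than the scatter. The estimate for compound 4 in this assay is 13000 nM, between 5500 nM and 30000 nM.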

Compound 4, half-maximal inhibitory concentration: 6230 nM
Beside the measured number, compound 4's estimate is 2.1-fold (0.32 log units) above it; the measured number falls inside the stated range.
By their numbers in this assay, from the lowest: compound 4; then compounds 2 and 1 (each within the scatter of the next). At a limit, above all of these: compound 3.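

Earlier changes on the amine nitrogen stayed within the scatter, but replacing 4-methylbenzyl with 4-bromobenzyl moves beyond it in this assay, with a 2.2-fold lower number from compound 2 to compound 4 (0.35 log units; beyond the scatter). This single-atom swap on the aromatic ring also sets compound 4 apart from the other two amines, with a 2.9-fold lower number from compound 1 to compound 4 (0.47 log units; beyond the scatter) and an at least 3.2-fold lower number from compound 3 to compound 4 (0.50 log units; beyond the scatter). The second of these steps is only a minimum, since compound 3 gives a limit and not a number: the limit of > 20000 nM in this assay, at which 1 of the 4 values shown sits.

One swap cannot show which feature of bromo matters. Going by these compounds, how chloro, methoxy or an amine would behave on this aromatic carbon remains open.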